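The source may report more compounds than this note shows. Statements on the series, on what has been measured and on what is new or still open speak of the compounds shown alone.

Among the measured compounds shown here, compound 2 `COc1ccc(-c2cc(/C=C/C(=O)c3ccc(C)c(C)c3)nc3cc(-c4ccccc4)nn23)cc1OC` is one of two compounds measured in an ADME assay on HEK293 cells (Homo sapiens) for antiproliferative activity, read by MTT assay, with a stated time of 24 h; a lower number here means a stronger inhibitor, a higher number a weaker inhibitor. In this assay, for the measured compounds named here, compound 2 gives 46200 nM, the lower of the two numbers, and its neighbour compound 1 `COc1ccc(-c2cc(C(=O)/C=C/c3ccc(C)cc3)nc3cc(-c4ccccc4)nn23)cc1OC` gives 57400 nM in the same assay; the only step between them, a 1.2-fold lower number from compound 1 to compound 2 (0.09 log units; within the scatter), does not exceed the scatter, so the two stand level. Compound 3 `COc1ccc(C(=O)/C=C/c2cc(-c3ccc(OC)c(OC)c3)n3nc(-c4ccccc4)cc3n2)cc1` has not yet been measured. It differs from compound 2 in one place: 4-methoxyphenyl in place of 3,4-dimethylphenyl on a carbonyl carbon. Going by the values given here, the single measured step, from compound 1 to compound 2, exchanges the direction of the linking group and its attached ring, a different kind of change, and it was small. The exchange of one aryl ring for another on the carbonyl carbon has no direct precedent among these compounds. On that basis a step in this assay no larger than the scatter is expected, with no clear direction, as a 1.0-fold lower number from compound 2 to compound 3 (0.00 log units; within the scatter). The estimate for compound 3 in this assay is therefore 46000 nM, with a range from 18000 nM to 120000 nM.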

Compound 3, half-maximal inhibitory concentration: 40000 nM
Beside the measured number, compound 3's estimate is 1.2-fold (0.06 log units) above it; low and high end bracket the measured number.
By their numbers in this assay, from the lowest: compounds 3, 2 and 1 (each within the scatter of the next).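

In this assay, putting 4-methoxyphenyl in place of 3,4-dimethylphenyl on the carbonyl carbon gives a 1.2-fold lower number from compound 2 to compound 3 (0.06 log units; within the scatter), so this first exchange of one aryl ring for another at this place stays inside the usual scatter, although the entering group has 1 hydrogen-bond acceptor and the leaving group has 0. The wider change on the aromatic carbon, which alters both the linking group and its ring, gives a 1.4-fold lower number from compound 1 to compound 3 (0.16 log units; within the scatter) and also stays inside the scatter, so all three compounds stand level and neither change can be said to have altered the result. No separate measurement is available to explain this outcome.

As far as these compounds go, whether a more different group on the carbonyl carbon, such as a phenyl ring carrying an amine or a carboxylic acid, or a saturated alkyl chain in place of the aryl ring, would move the number beyond the scatter remains open. Among the compounds shown here, with no step yet beyond the scatter, these compounds also leave open which parts of the structure this read-out depends on.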